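A quinoxaline in place of a quinoline

The compounds below may be only part of what the source reports. "The series", "measured", "known", "first", "only" and "open" are said of these compounds alone.

Compound 2 `CC(C)(C)c1ccc(-c2nc3c(N4CCN(Cc5ccc6ncccc6c5)CC4)cccc3[nH]2)cc1` gives 21 nM in an assay on isolated protein for displacement of a labelled ligand from Gonadotropin-releasing hormone receptor (Homo sapiens) (on this read-out higher numbers stand for weaker inhibition and lower numbers for stronger inhibition), the higher of the two numbers in hand; compound 1 `Cn1c(=O)c(=O)[nH]c2ccc(CN3CCN(c4cccc5[nH]c(-c6ccc(C(C)(C)C)cc6)nc45)CC3)cc21` gives 3.5 nM in this assay. Compound 3 `CC(C)(C)c1ccc(-c2nc3c(N4CCN(Cc5cccc6nccnc56)CC4)cccc3[nH]2)cc1` differs from compound 2 in one place: quinoxalin-5-yl in place of quinolin-6-yl on a saturated chain carbon bound to an amine nitrogen in a ring. Going by the values given here, no measured pair shows this particular swap, so nothing here says how large it is. The expected step from compound 2 to compound 3 in this assay is a 1.2-fold higher number from compound 2 to compound 3 (0.08 log units; within the scatter), with no direction beyond the scatter expected. Compound 3 is therefore estimated at 25 nM, within a range from 8 nM to 80 nM.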

Compound 3, half-maximal inhibitory concentration: 26 nM
Compound 3: middle estimate off by 1.0-fold (0.02 log units), on the low side; the range from low to high includes it.
By their numbers in this assay, from the lowest: compound 1; then compounds 2 and 3 (each within the scatter of the next).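

The step is a 1.2-fold higher number from compound 2 to compound 3 (0.09 log units; within the scatter) in this assay, so at this place the read-out does not separate the two groups. The swap adds a second ring nitrogen and changes the attachment point in the group's name, yet the number stays within the scatter. Nothing at hand explains why the two groups read alike. Still open, on these data alone, is whether each of those two differences alone would also leave the number in place. Also open, as far as these compounds go, is how a phenyl ring carrying an amine or a carboxylic acid would read here.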